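The source may hold more compounds than are shown below. What is called first, only, known or untested is meant among the compounds shown, and "the series" means these compounds.

Measured compounds:
compound 1 `CCCNc1nc(NCc2ccc(C(=O)Nc3ccc(F)cc3)cc2)c2cc(C)ccc2n1`, 1300 nM;
compound 2 `Cc1ccc2nc(N3CCNC(C)C3)nc(NCc3ccc(C(=O)NC4CCN(Cc5ccc(F)cc5)CC4)cc3)c2c1`, 1000 nM;
compound 3 `CNc1nc2ccccc2c(NCc2ccc(NC(=O)c3ccc(F)cc3)cc2)c1C#N`, > 20000 nM.

The three values come from a functional assay on SW480 cells (Homo sapiens) for inhibition, read by luminescence and resazurin assay, with a stated time of 3 days; on this read-out higher numbers stand for weaker inhibition and lower numbers for stronger inhibition. Compound 1 gives 1300 nM and compound 2 gives 1000 nM, and these two numbers lie within the usual scatter of each other. Compound 3 stands apart: its value of > 20000 nM is a limit of the assay and not a number, so it is only known to be the weakest inhibitor among the three measured compounds, as reflected by the limit of > 20000 nM in this assay, at which 1 of the 3 values shown sits.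

The step under study leads from compound 3 to compound 4 `CCCNc1nc2ccccc2c(NCc2ccc(NC(=O)c3ccc(F)cc3)cc2)c1C#N`. The change is ethyl in place of hydrogen on a saturated chain carbon bound to a nitrogen on an aromatic ring, which also reads as methylamino to propylamino. Going by the values given here, no step between measured compounds that differ in one place is at hand, so nothing on record tells how large a shift this exchange brings in this assay. Compound 1 does carry a propylamino group and gives 1300 nM, but its core differs from that of compound 3 in other ways, so that number is not a guide to this step.

Starting from a limit, the expected step from compound 3 to compound 4 is an at least 1.3-fold lower number from compound 3 to compound 4 (0.12 log units; that floor lies within the scatter), which is a modest gain at most, and a second limit is a real possibility. Compound 4 is therefore estimated at 15000 nM in this assay, with a range from 4000 nM to 60000 nM.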

Compound 4, half-maximal inhibitory concentration: > 20000 nM
Compound 4: no number, only a limit; the forecaster's own chance of this, stated with the estimate: 50%; middle value at least 1.3-fold (0.12 log units) from the limit.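

In this assay compound 4 gives > 20000 nM, a limit of the assay and not a number. Compound 3 and compound 4 both stand at a limit, so no step can be read between them: the limit of > 20000 nM in this assay, at which 2 of the 4 values shown sit.

The compounds shown leave open whether methylamino to propylamino on the shared core changes inhibition at all.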